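Exchanging the Sulfur Link for a Propyl Chain

This account rests on a few compounds, and the source may have more. Where it says the series, first, only, none or still open, it means among the compounds named here.

Compound 1 `CCSC(=S)SCC(=O)c1ccc(OC)cc1` holds the lowest of the three numbers in hand: in a functional assay on HeLa cells (Homo sapiens) for cytotoxicity, read by resazurin assay, with a stated time of 72 h (on this read-out lower numbers stand for stronger inhibition and higher numbers for weaker inhibition), compound 1 gives 1960 nM. Its two measured companions sit well away from it. Compound 2 `CCSC(=S)SCC(=O)c1ccc(C(=O)NCCOc2ccccc2)cc1` gives 18200 nM in this assay, and compound 3 `CCSC(=S)SCC(=O)c1ccc(CN(C)C(C)=O)cc1` gives 21500 nM. Going by the values given here, the single step that can be read within this set, an 11-fold higher number from compound 1 to compound 3 (1.04 log units; beyond the scatter), changes the group on the aromatic ring and leaves the thiocarbonyl end of the molecule untouched.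

Compound 4 `CCCC(=S)SCC(=O)c1ccc(OC)cc1` is not yet measured. It differs from compound 1 at the other end of the molecule: propyl in place of ethylsulfanyl on a thiocarbonyl carbon. Among the compounds with values here, no measured pair alters anything at the thiocarbonyl carbon, so the one known step concerns a different place and says nothing about exchanging ethylsulfanyl for propyl. The expectation is therefore weakly founded. Compound 4 keeps the rest of compound 1 unchanged, whose value of 1960 nM serves as the anchor, and the range is set wide to cover the lack of any precedent. For compound 4 the expected step is a 1.5-fold higher number from compound 1 to compound 4 (0.18 log units; within the scatter). Compound 4 is thus estimated at 3000 nM in this assay, with a range from 700 nM to 13000 nM.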

Compound 4, half-maximal inhibitory concentration: 5710 nM
Beside the measured number, compound 4's estimate is 1.9-fold (0.28 log units) below it; measured number inside the range.
By their numbers in this assay, from the lowest: compound 1; then compound 4; then compounds 2 and 3 (each within the scatter of the next).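

In this assay, going by these compounds alone, the exchange of ethylsulfanyl for propyl on a thiocarbonyl carbon gives a 2.9-fold higher number from compound 1 to compound 4 (0.46 log units; beyond the scatter) and so shows that this end of the molecule, left untouched in the earlier compounds, also bears on the read-out. The step is modest but beyond the scatter, and it comes from a swap that keeps the count of heavy atoms the same while a carbon takes the place of the sulfur and the hydrogen-bond acceptor counted for ethylsulfanyl is lost. Nothing measured here accounts for the change, and its origin remains unexplained.

From the compounds shown here alone, it remains open how methylsulfanyl, a longer chain, an amine or a carboxylic acid on this thiocarbonyl carbon would compare with the ethylsulfanyl of compound 1 and the propyl of compound 4. Going by these compounds, it also remains open whether the same exchange would give a step of similar size with the ring groups of compound 2 and compound 3 in place of the methoxy group.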